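The source may report more compounds than this note shows. Statements on the series, on what has been measured and on what is new or still open speak of the compounds shown alone.

Compound 1 `CCSC(=S)SCC(=O)c1cccc(NC(C)=O)c1` gives 10000 nM in a functional assay on HeLa cells (Homo sapiens) for antiproliferative activity, read by resazurin assay; on this read-out lower numbers stand for stronger inhibition and higher numbers for weaker inhibition.
Compound 2 `O=C(CSC(=S)Sc1ccccc1)c1ccc(Cl)c(Cl)c1` gives 20000 nM in this assay.
Compound 3 `CCSC(=S)SC(C)C(=O)c1ccccc1` gives 5010 nM in this assay.

Compound 1 sits between the other two values: compound 3 gives a lower number and compound 2 a higher one, but both gaps lie within the scatter of repeated measurements, so none of the three is set apart from the others. Compound 4 `CCOC(=O)Nc1cccc(C(=O)CSC(=S)SCC)c1` differs from compound 1 in one place, (ethoxy in place of methyl on a carbonyl carbon), which is to say ethoxy in place of methyl on a carbonyl carbon, acetamido becoming (ethoxycarbonyl)amino. Going by the values given here, no measured pair shows the effect of this change, so the expectation for this assay rests on the closeness of all three values: no step beyond the scatter in either direction. Compound 4 is therefore estimated at 10000 nM (between 4000 nM and 25000 nM), a step of no change at the digits printed from compound 1 to compound 4 (within the scatter) that is expected to stay within the scatter.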

Compound 4, half-maximal inhibitory concentration: 2000 nM
Beside the measured number, compound 4's estimate is 5.0-fold (0.70 log units) above it; the whole stated range lies above it.
By their numbers in this assay, from the lowest: compound 4; then compounds 3, 1 and 2 (each within the scatter of the next, the first and the last beyond it).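

Ethoxy in place of methyl on a carbonyl carbon, which turns acetamido into (ethoxycarbonyl)amino, gives a 5.0-fold lower number from compound 1 to compound 4 (0.70 log units; beyond the scatter) in this assay. This is the only step shown between compounds that differ in one place, and it shows that the read-out responds to a change at this position on the core of compound 1. No measurement available accounts for this step.

The compounds shown leave open whether the oxygen or the added carbons of the ethoxy carry the step, which methoxy or propyl on the same carbonyl carbon could separate. They also leave open how a dimethylamino group there would compare.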